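The source may hold more compounds than are shown below. What is called first, only, known or untested is meant among the compounds shown, and "the series" means these compounds.

Among the measured compounds shown here, compound 1 `c1ccc2c(c1)CN[C@@H](CN(CC1CCNCC1)[C@H]1CCCc3cccnc31)C2` is one of two compounds measured in an ADME assay on microsomes from liver (Mus musculus) for metabolic stability, read by LC-MS, with a stated time of 10 min, tested at 0.5 uM; on this read-out lower numbers stand for a less stable compound and higher numbers for a more stable compound. In this assay compound 1 gives 13%, the lowest of the two numbers available. For the measured compounds named here, the other measured compound, compound 2 `c1cnc2c(c1)CCC[C@@H]2N(CCCN1CCNCC1)Cc1nc2ccccc2s1`, gives in this assay 45%, a value that lies beyond the usual scatter above that of compound 1; the two structures differ in more than one place, so the two values are simply set side by side and no single step is drawn between them.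

Compound 3 `CN1CCN(CCCN(C[C@H]2Cc3ccccc3CN2)[C@H]2CCCc3cccnc32)CC1` has not yet been measured in this assay. It differs from compound 1 in one place: 2-(4-methylpiperazin-1-yl)ethyl in place of piperidin-4-yl on a saturated chain carbon bound to an amine nitrogen. Going by the values given here, no measured pair shows this change, so its effect on this assay rests only on the position of compound 1.

Because compound 1 gives 13%, compound 3 is expected to stay in the lower part of the range, with at most a modest rise expected as the step of a number 7 percentage points higher from compound 1 to compound 3 (within the scatter). Compound 3 is estimated to give 20% in this assay, expected between 5% and 45%.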

Compound 3, percent of the compound remaining: 53%
The estimate for compound 3 lay 33 percentage points below the measured number, and the stated range ends below it.
By their numbers in this assay, from the lowest: compound 1; then compounds 2 and 3 (each within the scatter of the next).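

Among the compounds shown here, the first step that changes only one place in the structure shows that the group on a saturated chain carbon bound to an amine nitrogen has a large bearing on the read-out in this assay: replacing piperidin-4-yl with 2-(4-methylpiperazin-1-yl)ethyl gives a number 40 percentage points higher from compound 1 to compound 3 (beyond the scatter) while the rest of the core of compound 1 stays the same. The change swaps a six-membered ring with 1 hetero atom and 1 hydrogen-bond donor for a larger group with a six-membered ring holding 2 hetero atoms and 0 hydrogen-bond donors, so the low value of compound 1 does not hold for every group at this place. Nothing available explains why the number rises with this change.

This single step leaves open which part of the change matters: the longer chain, the second ring nitrogen or the loss of the ring hydrogen-bond donor. As far as these compounds go, a 1-methylpiperidin-4-yl group or a morpholine ring on the same propyl chain would help to tell these parts apart, and how the change would carry over to other cores also remains open.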